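Swapping the substituted phenyl arm of compound 3

The compounds below may be only part of what the source reports. "The series", "measured", "known", "first", "only" and "open" are said of these compounds alone.

Three compounds share one core. Compound 1 `O=C1c2ccc(OCc3cccc(-c4ccccc4)c3)cc2CN1C1CCCC1` gives "not determined" (no result reported) in an assay on HEK293 cells for positive allosteric modulation of metabotropic glutamate receptor 2 (Rattus norvegicus), read by thallium flux (on this read-out higher numbers stand for larger maximal responses and lower numbers for smaller maximal responses), and compound 2 `O=C1c2ccc(OCc3cccc(-c4ccc(C(F)(F)F)cc4F)c3)cc2CN1C1CCCC1` gives "not determined" (no result reported) in this assay; for both, no result was reported. Within the data shown here, compound 3 `COc1ccc(-c2cccc(COc3ccc4c(c3)CN(C3CCCC3)C4=O)c2)cc1C(=O)O` is the only member with a value: in this assay compound 3 reaches 78%, so it stands alone as the single point of reference. Compound 4 `O=C(O)c1cc(F)cc(-c2cccc(COc3ccc4c(c3)CN(C3CCCC3)C4=O)c2)c1` is not yet measured. It differs from compound 3 in one place, (3-carboxy-5-fluorophenyl in place of 3-carboxy-4-methoxyphenyl on an aromatic carbon), with the change sitting on an aromatic carbon of a six-membered aromatic ring of carbon only, meta to a large group. Among the measured compounds shown here, with no step between measured compounds to lean on, the expectation is a change within the usual scatter, expressed as a number 3 percentage points lower from compound 3 to compound 4 (within the scatter). Compound 4 is therefore estimated at 75%, in a range from 55% to 95%.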

Compound 4, largest response reached (reported as percent of maximum), in percent of the reference or control that the assay uses: 80.8%
Compound 4: the middle estimate sits 5.8 percentage points below what was measured, and the stated range covers the measured number.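

In this assay, exchanging 3-carboxy-4-methoxyphenyl for 3-carboxy-5-fluorophenyl gives a number 2.8 percentage points higher from compound 3 to compound 4 (within the scatter), so the two arms cannot be told apart on this read-out. The maximal response therefore survives a change on this ring that removes the methoxy group and brings in a fluorine, which a single measured compound could not show. Nothing measured here explains this outcome. Compounds 1 and 2 lack the carboxylic acid but have no result, so its contribution cannot be read. From the compounds shown here alone, whether an amine or a tetrazole could stand in its place remains open.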